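The source may report more compounds than this note shows. Statements on the series, on what has been measured and on what is new or still open speak of the compounds shown alone.

Among the measured compounds shown here, compound 3 `Cn1ncc(Cl)c1-c1cc(C(=O)N[C@@H]2CN[C@H](CCn3cncn3)C[C@H]2c2ccc(Cl)c(Cl)c2)oc1Cl` carries the highest of the three numbers measured so far in an assay for inhibition of RAC-alpha serine/threonine-protein kinase (Homo sapiens), read by HTRF, with a stated time of 1 h (on this read-out lower numbers stand for stronger inhibition and higher numbers for weaker inhibition), where compound 3 gives 4.47 nM, though all three lie within the scatter of one another: compound 1 `Cn1ncc(Cl)c1-c1cc(C(=O)N[C@@H]2CN[C@H](CC(O)CO)C[C@H]2c2ccc(Cl)c(Cl)c2)oc1Cl` gives 3.79 nM and compound 2 `Cn1ncc(Cl)c1-c1cc(C(=O)N[C@@H]2CN[C@H](CCCO)C[C@H]2c2ccc(Cl)c(Cl)c2)oc1Cl` gives 2.56 nM. Compound 4 `Cn1ncc(Cl)c1-c1cc(C(=O)N[C@@H]2CN[C@H](CCN3CCCCC3)C[C@H]2c2ccc(Cl)c(Cl)c2)oc1Cl` differs from compound 3 by piperidin-1-yl in place of 1H-1,2,4-triazol-1-yl on a saturated chain carbon, two bonds along the chain from a saturated ring carbon. The measured steps that bear on this place are a 1.7-fold higher number from compound 2 to compound 3 (0.24 log units; within the scatter) and a 1.2-fold higher number from compound 1 to compound 3 (0.07 log units; within the scatter), both within the scatter, so changes at this end of the chain have so far left this assay nearly unmoved. For the measured compounds named here, no measured step exchanges one ring for another here, so the expectation rests only on that tolerance. Compound 4 is therefore expected to show a 1.0-fold higher number from compound 3 to compound 4 (0.00 log units; within the scatter), that is an estimated 4.5 nM, between 1.5 nM and 14 nM.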

Compound 4, half-maximal inhibitory concentration: 5.65 nM
Beside the measured number, compound 4's estimate is 1.3-fold (0.10 log units) below it; the measured number falls inside the stated range.
By their numbers in this assay, from the lowest: compounds 2, 1, 3 and 4 (each within the scatter of the next, the first and the last beyond it).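

Piperidin-1-yl in place of 1H-1,2,4-triazol-1-yl gives a 1.3-fold higher number from compound 3 to compound 4 (0.10 log units; within the scatter) in this assay, and with a 1.5-fold higher number from compound 1 to compound 4 (0.17 log units; within the scatter) this shows that a six-membered non-aromatic ring is tolerated on this saturated chain carbon. Only a 2.2-fold higher number from compound 2 to compound 4 (0.34 log units; beyond the scatter) lies beyond the scatter, a modest step and the first at this end of the chain to do so. Nothing available explains these differences.

On these data alone, whether morpholin-4-yl, dimethylamino or a carboxylic acid at this chain end would keep the number in the same range remains open.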